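This account rests on a few compounds, and the source may have more. Where it says the series, first, only, none or still open, it means among the compounds named here.

Values in a functional assay on SK-OV-3 cells (Homo sapiens) for inhibition, read by sulforhodamine B assay, with a stated time of 48 h; on this read-out higher numbers stand for weaker inhibition of growth and lower numbers for stronger inhibition of growth:
- Compound 1 `O=C(Cc1csc2nc(-c3ccc(Br)cc3)cn12)N/N=C/c1ccccc1O`: 30200 nM
- Compound 2 `O=C(Cc1csc2nc(-c3ccc(Br)cc3)cn12)N/N=C/c1ccc(O)cc1`: > 100000 nM (a limit)
- Compound 3 `COc1cccc(OC)c1/C=N/NC(=O)Cc1csc2nc(-c3ccc(Br)cc3)cn12`: > 100000 nM (a limit)

Compound 3 gives no number and stands on (the limit of > 100000 nM in this assay, at which 2 of the 3 values shown sit). The next compound, compound 4 `O=C(Cc1csc2nc(-c3ccc(Br)cc3)cn12)N/N=C/c1ccc(Cl)cc1Cl`, has 2,4-dichlorophenyl in place of 2,6-dimethoxyphenyl on a carbon with a double bond to nitrogen.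

Going by the values given here, two measured steps bear on this change, both leaving the 2-hydroxyphenyl of compound 1. They are an at least 3.3-fold higher number from compound 1 to compound 2 (0.51 log units; beyond the scatter) and an at least 3.3-fold higher number from compound 1 to compound 3 (0.51 log units; beyond the scatter), each at least modest and beyond the scatter. The remaining step, a step that the two limits leave unreadable from compound 2 to compound 3, cannot be read. Compound 4 also lacks the 2-hydroxyphenyl, so it is expected to resemble compound 2 and compound 3 rather than compound 1 in this assay. A result at the limit is the likeliest outcome, and any measurable shift would be toward a lower number, with only a small step expected. The estimated step is an at least 1.2-fold lower number from compound 3 to compound 4 (0.09 log units; that floor lies within the scatter). The estimate for compound 4 is 80000 nM, with an expected range of 30000 nM to 100000 nM.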

Compound 4, concentration for total growth inhibition: > 100000 nM
Compound 4: a limit, no number; the forecaster's own chance of this, stated with the estimate: 60%; middle value at least 1.2-fold (0.09 log units) away from the limit.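

In this assay compound 4 gives > 100000 nM, which is a limit and not a number. Placing 2,4-dichlorophenyl on the carbon with a double bond to nitrogen in place of 2-hydroxyphenyl gives an at least 3.3-fold higher number from compound 1 to compound 4 (0.51 log units; beyond the scatter), so the move away from compound 1 now holds for a ring with no hydrogen-bond donors or acceptors, as well as for the oxygen-bearing rings of compound 2 and compound 3. The steps among compound 2, compound 3 and compound 4 cannot be read, and these compounds cannot be ranked: the limit of > 100000 nM in this assay, at which 3 of the 4 values shown sit.

From the compounds shown here alone, only compound 1 gives a number, so it remains open whether any group other than 2-hydroxyphenyl can hold a measurable value here. A 2-aminophenyl or a 2-carboxyphenyl in this place would test that.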